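Swapping the Side-Chain Hydroxy Group of Compound 1

The compounds below may be only part of what the source reports. "The series", "measured", "known", "first", "only" and "open" are said of these compounds alone.

Compound 1, `O=C1O[C@@H](CO)CN1c1ccc(-n2cc(-c3ccccn3)cn2)c(F)c1`: 59 ug/mL
Compound 2, `O=C1O[C@@H](CSc2cccs2)CN1c1ccc(-n2cc(-c3ccccn3)cn2)c(F)c1`: > 400 ug/mL
Compound 3, `O=CNC[C@H]1CN(c2ccc(-n3cc(-c4ccccn4)cn3)c(F)c2)C(=O)O1`: > 400 ug/mL

For the measured compounds named here, in an ADME assay on L02 cells (Homo sapiens) for cytotoxicity, read by MTT assay, with a stated time of 48 h (on this read-out lower numbers stand for stronger inhibition and higher numbers for weaker inhibition), compound 1 gives 59 ug/mL, the only plain number among the three. The value of compound 2 is a limit of the assay. The value of compound 3 is also a limit, so two readings sit at the limit of > 400 ug/mL in this assay, at which 2 of the 3 values shown sit. Both replacements of the hydroxy group moved the read-out the same way: an at least 6.7-fold higher number from compound 1 to compound 2 (0.83 log units; beyond the scatter) and an at least 6.7-fold higher number from compound 1 to compound 3 (0.83 log units; beyond the scatter). Compound 4, `CCNC(=O)NC[C@H]1CN(c2ccc(-n3cc(-c4ccccn4)cn3)c(F)c2)C(=O)O1`, carries a related change: (ethylcarbamoyl)amino in place of hydroxy on a saturated chain carbon bound to a saturated ring carbon. The step from compound 1 to compound 3 is the nearest guide, so compound 4 is expected to follow it, a 5.1-fold higher number from compound 1 to compound 4 (0.71 log units; beyond the scatter). Compound 4 is estimated at 300 ug/mL, between 120 ug/mL and 600 ug/mL, with a fair chance that only a limit is reported.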

Compound 4, half-maximal inhibitory concentration: > 400 ug/mL
Compound 4 gave a limit, no number; the forecaster's own chance of this, stated with the estimate: 60%; middle value at least 1.3-fold (0.12 log units) away from the limit.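

In this assay, (ethylcarbamoyl)amino is a third replacement of hydroxy on this saturated chain carbon that moves the read-out the same way, giving an at least 6.7-fold higher number from compound 1 to compound 4 (0.83 log units; beyond the scatter). This holds for a larger, urea-type chain as well as for formylamino and (thiophen-2-yl)sulfanyl. Compound 4 gives a limit, not a number: the limit of > 400 ug/mL in this assay, at which 3 of the 4 values shown sit.

The steps among compound 2, compound 3 and compound 4 cannot be read, so the three replacements cannot be ranked. As far as these compounds go, how a plain amine or a carboxylic acid on the same carbon would read remains open.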